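Trifluoromethylphenyl for dichlorophenyl: cytotoxicity expected to stay at limit

The source may report more compounds than this note shows. Statements on the series, on what has been measured and on what is new or still open speak of the compounds shown alone.

Compound 1 `O=C(Nc1cccc(-n2cc(-c3ccncc3)c(-c3ccc(Cl)c(O)c3)n2)c1)Nc1cccc(C(F)(F)F)c1` gives > 32500 nM in a functional assay on RPMI-8226 cells (Homo sapiens) for inhibition, read by sulforhodamine B assay, with a stated time of 48 h; on this read-out higher numbers stand for lower toxicity in this test and lower numbers for higher toxicity in this test; this is a limit of the assay and not a number.
Compound 2 `COc1cc(-c2nn(-c3cccc(NC(=O)c4cccc(C(F)(F)F)c4)c3)cc2-c2ccncc2)ccc1Cl` gives > 50000 nM in this assay, also a limit.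
Compound 3 `COc1cc(-c2nn(-c3cccc(NC(=O)Nc4ccc(Cl)c(Cl)c4)c3)cc2-c2ccncc2)ccc1Cl` gives > 50000 nM in this assay, again a limit.

Compound 3 thus stands at the limit of > 50000 nM in this assay, at which 2 of the 3 values shown sit, shared with compound 2, while compound 1 sits at the limit of > 32500 nM in this assay, at which 1 of the 3 values shown sits. Within the data shown here, the only step touching compound 3, a step that the two limits leave unreadable from compound 2 to compound 3, cannot be read because both ends are limits. Compound 4 `COc1cc(-c2nn(-c3cccc(NC(=O)Nc4cccc(C(F)(F)F)c4)c3)cc2-c2ccncc2)ccc1Cl` differs from compound 3 by 3-(trifluoromethyl)phenyl in place of 3,4-dichlorophenyl on an amide-type nitrogen. Among the measured compounds shown here, no measured step reads the size of this change. Compound 1, which carries the same 3-(trifluoromethyl)phenyl urea on a different core, also reaches only a limit. Compound 4 is therefore expected to give 50000 nM, between 20000 nM and 120000 nM, most likely again reported as a limit. The expected step of a number no higher from compound 3 to compound 4 (the limit leaves the size open) is estimated to be none beyond the scatter.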

Compound 4, concentration lethal to 50% of the cells: > 50000 nM
Compound 4: no number, only a limit (the forecaster's own chance of this, stated with the estimate: 85%); the middle value sits exactly at the limit.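

Among these compounds, compound 1, compound 2, compound 3 and compound 4 all give only limits in this assay, and no step among them can be read. The compounds shown leave open whether 3-(trifluoromethyl)phenyl in place of 3,4-dichlorophenyl changes toxicity at all.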